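Acylthiourea series: cytotoxicity, carbonyl substituent swapped for propyl

A few compounds are considered here, and "the series" means these few. Any claim that something is new, unique, unknown or untested is made for them only; others in the source may bear on it.

Measured compounds:
compound 1 `O=C(NC(=S)N1CCc2c(OCCCCCOc3ccc(Cl)cc3)cccc21)Oc1ccccc1`: > 50000 nM
compound 2 `O=C(NC(=S)N1CCc2c(OCCCCCOc3ccc(Cl)cc3)cccc21)c1ccc(C(F)(F)F)cc1`: 32700 nM
compound 3 `CN(C)c1ccc(C(=O)NC(=S)N2CCc3c(OCCCCCOc4ccc(Cl)cc4)cccc32)cc1`: > 50000 nM

In an ADME assay on Huh-7 cells (Homo sapiens) for cytotoxicity (a higher number here means that more compound is tolerated, a lower number that less compound is tolerated), compound 1 reaches > 50000 nM, which is a limit of the assay and not a number. Compound 2 gives 32700 nM in this assay. For compound 3 the result > 50000 nM is again a limit of the assay. The steps among the three read an at least 1.5-fold lower number from compound 1 to compound 2 (0.18 log units; that floor lies within the scatter), a step that the two limits leave unreadable from compound 1 to compound 3 and an at least 1.5-fold higher number from compound 2 to compound 3 (0.18 log units; that floor lies within the scatter); none of them is beyond the scatter, and compound 3 sits at the limit of > 50000 nM in this assay, at which 2 of the 3 values shown sit.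

Compound 4 `CCCC(=O)NC(=S)N1CCc2c(OCCCCCOc3ccc(Cl)cc3)cccc21` is the next analogue: propyl in place of 4-(dimethylamino)phenyl on a carbonyl carbon. For the measured compounds named here, every measured step changes the group on the same carbonyl carbon, yet none exchanges an aromatic group for a chain, so no step bears directly on this change. Since all three measured steps stay within the scatter or are unreadable, the step expected from compound 3 to compound 4 is a number no higher from compound 3 to compound 4 (the limit leaves the size open), with no movement beyond the scatter. Compound 4 is therefore estimated at 50000 nM, within 25000 nM to 100000 nM, most likely reported again as a limit.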

Compound 4, half-maximal cytotoxic concentration: > 50000 nM
Compound 4: a limit, no number (the forecaster's own chance of this, stated with the estimate: 60%); the middle value sits exactly at the limit.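

In this assay, for the compounds shown here, the result for compound 4 is a limit and not a number, and it shows for the first time that a chain with no ring, propyl, on this carbonyl carbon reads the same as phenoxy and 4-(dimethylamino)phenyl: the limit of > 50000 nM in this assay, at which 3 of the 4 values shown sit. Going by these compounds alone, the one step that can be read is an at least 1.5-fold higher number from compound 2 to compound 4 (0.18 log units; that floor lies within the scatter), so exchanging 4-(trifluoromethyl)phenyl for propyl gives no movement beyond the scatter. The steps to compound 4 from compound 1 and from compound 3 cannot be read, as both ends of each are limits.

As far as these compounds go, how the true values of compound 1, compound 3 and compound 4 compare remains open. Also open, from the compounds shown here alone, is whether a longer chain, or a chain carrying an amine, on this carbonyl carbon would stay at the limit.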